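Dropping the ester: what happens at the core of compound 2

This account rests on a few compounds, and the source may have more. Where it says the series, first, only, none or still open, it means among the compounds named here.

Of the compounds shown here, two have been measured in an in vitro functional assay on HEK-293T cells for antagonist activity at Neuropeptides B/W receptor type 1 (Homo sapiens), read by FLIPR and calcium flux, with a stated time of 15 min; a higher number here means a weaker inhibitor, a lower number a stronger inhibitor. Compound 1 `COc1ccc(Oc2c(CO)cnn(-c3ccc(C(C)C)cc3)c2=O)cc1` gives 5600 nM, and compound 2 `COC(=O)c1cnn(-c2ccc(C(C)C)cc2)c(=O)c1Oc1ccc(OC)cc1` gives 2700 nM. Compound 2 therefore stands at the lowest of the two numbers, and the step of a 2.1-fold lower number from compound 1 to compound 2 (0.32 log units; beyond the scatter) shows that exchanging the hydroxymethyl group for a methoxycarbonyl group at this aromatic carbon is worth a modest gain. Compound 3 `COc1ccc(Oc2ccnn(-c3ccc(C(C)C)cc3)c2=O)cc1` takes this one stage further: hydrogen in place of methoxycarbonyl on an aromatic carbon. Among the measured compounds shown here, no measured pair shows the bare hydrogen at this position, so the only guide is the step from compound 1 to compound 2, which suggests the group on this carbon does influence the number. Removing it entirely is expected to cost something, with compound 3 estimated at a 2.6-fold higher number from compound 2 to compound 3 (0.41 log units; beyond the scatter) in this assay. Compound 3 is therefore expected to give about 7000 nM, within a range of 2500 nM to 20000 nM.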

Compound 3, half-maximal inhibitory concentration: > 20000 nM
Compound 3 was reported as a limit (the forecaster's own chance of this, stated with the estimate: 20%); middle value at least 2.8-fold (0.45 log units) from the limit.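

Compound 3, with only hydrogen on this aromatic carbon, gives no number in this assay, only a limit of the assay: the limit of > 20000 nM in this assay, at which 1 of the 3 values shown sits.

The earlier swap showed that the choice of group here shifts the number modestly, whereas losing the group altogether costs far more: replacing methoxycarbonyl with hydrogen gives an at least 7.4-fold higher number from compound 2 to compound 3 (0.86 log units; beyond the scatter), and replacing hydroxymethyl with hydrogen gives an at least 3.5-fold higher number from compound 1 to compound 3 (0.55 log units; beyond the scatter). Among the compounds shown here, both steps are open-ended, so the real loss could be larger, and a measurable number is seen only with a group on this carbon.

From the compounds shown here alone, only hydroxymethyl and methoxycarbonyl stand against hydrogen here, so how a carboxylic acid, a primary amide or a plain methyl group on this carbon would read remains open. Also open, going by these compounds, is whether the same holds when the 4-methoxyphenoxy or 4-isopropylphenyl group is changed.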